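Phenyl Added to a Lactone: Expected Cost in Potency

The compounds below may be only part of what the source reports. "The series", "measured", "known", "first", "only" and "open" are said of these compounds alone.

Of the compounds shown here, two of a shared core have been tested so far. Compound 1 `CC(=O)O[C@@H]1OC(=O)[C@](Cc2ccccc2)(C(C)=O)[C@@H]1C` carries a benzyl group on the quaternary ring carbon and in a functional assay on HT-29 cells (Homo sapiens) for cytotoxicity, read by MTT assay (a lower number here means a stronger inhibitor, a higher number a weaker inhibitor), compound 1 gives 40000 nM. Compound 2 `CC(=O)O[C@@H]1OC(=O)[C@@](C)(C(C)=O)[C@@H]1C` carries a methyl at the same position, and in this assay compound 2 gives 12000 nM, the lowest of the two numbers seen, with compound 1 standing a gap beyond the scatter above it.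

Compound 3 `CC(=O)O[C@@H]1OC(=O)[C@@](Cc2ccccc2)(C(C)=O)[C@@H]1C` is the next step from compound 2: phenyl in place of hydrogen on a saturated chain carbon bound to a saturated ring carbon, which read one bond further out is a methyl becoming a benzyl. Among the measured compounds shown here, no step between measured compounds is recorded, so the size of this change cannot be taken from a direct comparison. The numbers for compound 1 and compound 2 suggest that a benzyl-bearing member of this series tends to give the higher number, though compound 1 and compound 3 are not otherwise identical and that comparison stays loose.

Compound 3 is therefore expected to be a weaker inhibitor than compound 2, estimated at 30000 nM with a range of 10000 nM to 90000 nM, a step of a 2.5-fold higher number from compound 2 to compound 3 (0.40 log units; beyond the scatter) beyond the scatter.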

Compound 3, half-maximal inhibitory concentration: 39000 nM
Compound 3: the middle estimate sits 1.3-fold (0.11 log units) below what was measured; low and high end bracket the measured number.
By their numbers in this assay, from the lowest: compound 2; then compounds 3 and 1 (each within the scatter of the next).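

In this assay, the change from methyl to benzyl at this position now has a directly measured size: a 3.3-fold higher number from compound 2 to compound 3 (0.51 log units; beyond the scatter). The earlier pair could not give this reading, as compound 1 and compound 2 differ in more than the group at this position. The other step, a 1.0-fold lower number from compound 1 to compound 3 (0.01 log units; within the scatter), shows that swapping the configuration drawn at the saturated ring carbon makes no difference beyond the scatter for these two benzyl compounds, and this comparison is a clean one on a single point: the fact that compounds 1 and 3 differ only in the configuration as drawn

The compounds shown leave open whether configuration at this carbon is equally unimportant when the group there is a methyl, as the methyl appears in one configuration only. On these data alone, it also remains open how a longer chain, or a chain ending in an amine or a carboxylic acid, would read at this position, and whether any such group would give a number lower than that of compound 2.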